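A Dimethylcarbamoyl Group at a Cytotoxicity Ceiling

A few compounds are considered here, and "the series" means these few. Any claim that something is new, unique, unknown or untested is made for them only; others in the source may bear on it.

Compound 1 `c1ccc(-c2ccc(Cn3cncc3CNc3cccc(-c4ccccc4)c3)cc2)cc1` was tested in a toxicity assay on NIH3T3 cells (Mus musculus) for cytotoxicity, read by resazurin assay (on this read-out higher numbers stand for an effect only at larger amounts of compound and lower numbers for an effect already at smaller amounts), where compound 1 gives 10000 nM. Compound 3 `O=[N+]([O-])c1ccc(Cn2cncc2CNc2cccc(-c3ccccc3)c2)cc1` carries a nitro group in place of the phenyl group of compound 1, and in this assay compound 3 gives 10000 nM. The step of no change at the digits printed from compound 1 to compound 3 (within the scatter) thus left the value where it stood. Compound 2 `COC(=O)c1ccc(NCc2cncn2Cc2cccc([N+](=O)[O-])c2)cc1-c1ccccc1` was also run in this assay, and for compound 2 the result of > 10000 nM is a limit of the assay rather than a number. Compound 1 therefore stands level with compound 3, and the limit of > 10000 nM in this assay, at which 1 of the 3 values shown sits, marks the edge of what the assay resolves here.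

Compound 4 `CN(C)C(=O)c1ccc(NCc2cncn2Cc2ccc(-c3ccccc3)cc2)cc1-c1ccccc1` differs from compound 1 in one place: dimethylcarbamoyl in place of hydrogen on an aromatic carbon. Within the data shown here, no measured step introduces a group at this place, so the only guides are the single measured step, which was flat, and the fact that all three known values sit at or beyond the same ceiling. The dimethylcarbamoyl group is consequently expected to leave the read-out unchanged, with no change at the digits printed from compound 1 to compound 4 (within the scatter) amounting to no step beyond the scatter. Compound 4 is estimated to give 10000 nM in this assay, within a range of 5000 nM to 20000 nM, with a real chance that only a limit is reported.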

Compound 4, half-maximal effective concentration: > 1000 nM
Compound 4 was reported as a limit; the forecaster's own chance of this, stated with the estimate: 50%; the middle value is on the limit's open side.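

In this assay, among these compounds, compound 4 gives > 1000 nM, which is a limit of the assay and not a number, so no step from compound 1 to compound 4 can be read. The compounds shown leave open where compound 4 stands relative to compound 1, and so whether dimethylcarbamoyl in place of hydrogen shifts the read-out at all.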